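This account rests on a few compounds, and the source may have more. Where it says the series, first, only, none or still open, it means among the compounds named here.

Within the data shown here, compound 1, `O=S(=O)(NCCNc1nccc(-c2c(-c3cccc(F)c3)nc3sccn23)n1)c1ccc(Br)cc1`, is one of two compounds measured in a functional assay on A-375 cells (Homo sapiens) for cytotoxicity, read by MTT assay; a lower number here means a stronger inhibitor, a higher number a weaker inhibitor. In this assay compound 1 gives 13500 nM, the higher of the two numbers. Compound 2, `O=S(=O)(NCCCNc1nccc(-c2c(-c3cccc(F)c3)nc3sccn23)n1)c1ccc(C(F)(F)F)cc1`, gives 4090 nM in this assay, and the gap between these two values lies beyond the usual scatter. Compound 2 differs from compound 1 in more than one place, so the two values cannot be tied to a single structural change.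

Compound 3, `O=C(NCCNc1nccc(-c2c(-c3cccc(F)c3)nc3sccn23)n1)c1ccc(Cl)cc1`, has not yet been measured. It differs from compound 1 in one place: (4-chlorophenyl)carbonyl in place of (4-bromophenyl)sulfonyl on an amine nitrogen. Among the measured compounds shown here, no measured pair shows what this kind of exchange does in this assay, so the direction of its effect is unknown. For the measured compounds named here, with no such pair available, the expected step is a 1.4-fold lower number from compound 1 to compound 3 (0.13 log units; within the scatter), within the usual scatter. Compound 3 is expected to give about 10000 nM in this assay, with a range from 3000 nM to 35000 nM.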

Compound 3, half-maximal inhibitory concentration: 2570 nM
Beside the measured number, compound 3's estimate is 3.9-fold (0.59 log units) above it; the whole stated range lies above it.
By their numbers in this assay, from the lowest: compounds 3 and 2 (each within the scatter of the next); then compound 1.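

Among these compounds, at this amine nitrogen, replacing (4-bromophenyl)sulfonyl with (4-chlorophenyl)carbonyl gives a 5.3-fold lower number from compound 1 to compound 3 (0.72 log units; beyond the scatter) in this assay, the first change that can be tied to a single place. The result shows that the number in this assay responds to the group on this nitrogen, even though the shared core and the ethylene chain stay the same. Nothing available here explains the drop in the number.

The exchange swaps sulfonyl for carbonyl and bromine for chlorine together, so the compounds shown cannot say which of the two carries the step, or whether both contribute. A (4-bromophenyl)carbonyl group on the same nitrogen would separate these two changes, while a plain benzoyl group would show whether the ring needs a halogen at all.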